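Swapping trifluoromethyl for nitro on the shared core

The compounds below may be only part of what the source reports. "The series", "measured", "known", "first", "only" and "open" are said of these compounds alone.

Measured so far:
Compound 1 `CC(c1ccc(-c2ccccc2)c(F)c1)c1nnc2n1N=C(c1ccc(C(F)(F)F)cc1)CS2`: 6100 nM
Compound 2 `CC(C)Cc1ccc(C(C)c2nnc3n2N=C(c2ccc(F)cc2)CS3)cc1`: 12400 nM

In a functional assay on HCT-116 cells (Homo sapiens) for inhibition, read by sulforhodamine B assay, with a stated time of 72 h (on this read-out higher numbers stand for weaker inhibition and lower numbers for stronger inhibition), compound 1 gives 6100 nM, the lowest of the two numbers, with compound 2 at 12400 nM beyond the scatter above it. Compound 3 `CC(c1ccc(-c2ccccc2)c(F)c1)c1nnc2n1N=C(c1ccc([N+](=O)[O-])cc1)CS2` keeps the core of compound 1 and differs by nitro in place of trifluoromethyl on an aromatic carbon. For the measured compounds named here, no measured pair shows this exchange, so nothing in the data sets its size. Compound 3 is expected to stay close to compound 1, with a step of a 1.2-fold lower number from compound 1 to compound 3 (0.09 log units; within the scatter), and an estimated value of 5000 nM, within 1500 nM to 15000 nM.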

Compound 3, half-maximal inhibitory concentration: 7100 nM
For compound 3 the middle estimate is 1.4-fold (0.15 log units) below the measured one, and the stated range covers the measured number.
By their numbers in this assay, from the lowest: compounds 1, 3 and 2 (each within the scatter of the next, the first and the last beyond it).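

In this assay, for the compounds shown here, the exchange gives a 1.2-fold higher number from compound 1 to compound 3 (0.07 log units; within the scatter) and so offers the first comparison that changes one place only. On this aromatic carbon, para to a large group, nitro and trifluoromethyl cannot be told apart, so the position accepts either group without a change beyond the scatter. As far as these compounds go, whether an amine or a carboxylic acid in the same place would also leave the number unchanged stays open, since both groups tested here give similar results. No measurement shown here accounts for this similarity.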